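The source may report more compounds than this note shows. Statements on the series, on what has been measured and on what is new or still open speak of the compounds shown alone.

Compound 1 `COc1ccc(-c2csc(N3N=C(c4ccc(C)cc4)CC3c3ccc4c(c3)OCCO4)n2)cc1`: 2870 nM
Compound 2 `COc1ccc(C2=NN(c3nc(-c4ccc(OC)cc4)cs3)C(c3ccc4c(c3)OCCO4)C2)cc1`: 3010 nM

In a functional assay on B16-F10 cells (Mus musculus) for antiproliferative activity, read by MTT assay, with a stated time of 48 h (a lower number here means a stronger inhibitor, a higher number a weaker inhibitor), compound 1 holds the lower of the two numbers, though compound 2 lies within the scatter of it, as the step of a 1.0-fold higher number from compound 1 to compound 2 (0.02 log units; within the scatter) shows. Compound 3 `COc1ccc(-c2csc(N3N=C(c4ccc(Cl)cc4)CC3c3ccc4c(c3)OCCO4)n2)cc1` differs from compound 1 by chloro in place of methyl on an aromatic carbon. Within the data shown here, the one measured step, a 1.0-fold higher number from compound 1 to compound 2 (0.02 log units; within the scatter), also replaced the methyl at that aromatic carbon and stayed within the scatter; no measured step involves chloro. The expectation for compound 3 is therefore a step of a 1.1-fold lower number from compound 1 to compound 3 (0.03 log units; within the scatter) in this assay, not beyond the scatter. Compound 3 is estimated at 2700 nM, with a range from 1200 nM to 6000 nM.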

Compound 3, half-maximal inhibitory concentration: 3120 nM
Compound 3: middle estimate off by 1.2-fold (0.06 log units), on the low side; the measured number falls inside the stated range.
By their numbers in this assay, from the lowest: compounds 1, 2 and 3 (each within the scatter of the next).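

In this assay, chloro now stands with methyl and methoxy on the aromatic carbon para to a large group: the step of a 1.1-fold higher number from compound 1 to compound 3 (0.04 log units; within the scatter) and the step of a 1.0-fold higher number from compound 2 to compound 3 (0.02 log units; within the scatter) both lie within the scatter. All three groups at this position therefore give the same reading within the scatter, and the change from 4-methylphenyl to 4-chlorophenyl has no visible effect on it. No evidence is available to explain this result. From the compounds shown here alone, whether an amine, a carboxylic acid or a longer chain here would give a step beyond the scatter stays open. So does whether changes elsewhere on the shared core would do so.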